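Chloro on the benzyl arm of compound 3

A few compounds are considered here, and "the series" means these few. Any claim that something is new, unique, unknown or untested is made for them only; others in the source may bear on it.

The measured compounds and their values:
compound 1, `COc1ccc(C2N=C(SCc3ccccc3)NC(C)=C2C(=O)Nc2ccc(F)cc2)cc1OC`, 1%
compound 2, `COc1ccc(C2N=C(SCc3ccc(F)cc3)NC(C)=C2C(=O)Nc2ccc(F)cc2)cc1OC`, 15.4%
compound 3, `CC1=C(C(=O)Nc2ccc([N+](=O)[O-])cc2)C(c2ccc(Br)cc2)N=C(SCc2ccccc2)N1`, 19.5%

In a functional assay on the whole organism (artery, strain albino) with Rattus norvegicus as the target, with a stated time of 900 min, at a dose of 10 mg/kg by the oral route (a higher number here means more inhibition at the dose given (going by the name of the read-out), a lower number less inhibition), compound 3 gives 19.5%, the highest of the three numbers; compound 2 lies within the scatter of it, while compound 1 lies beyond the scatter below it. Compound 4, `CC1=C(C(=O)Nc2ccc([N+](=O)[O-])cc2)C(c2ccc(Br)cc2)N=C(SCc2ccc(Cl)cc2)N1`, is not yet measured. It differs from compound 3 in one place: chloro in place of hydrogen on an aromatic carbon. Among the measured compounds shown here, the one measured step that bears on this change is a number 14.4 percentage points higher from compound 1 to compound 2 (beyond the scatter), where a halogen likewise entered on the benzylsulfanyl ring of the shared core; it was a modest rise beyond the scatter. On that single precedent, compound 4 is expected to move in the same direction by a similar or somewhat smaller amount, a number 7.5 percentage points higher from compound 3 to compound 4 (within the scatter). Compound 4 is therefore estimated at 27% in this assay, in a range from 12% to 42%.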

Compound 4, a percentage reported as inhibition, in the whole organism at one dose (the size of the read-out at that dose, not a potency): 19%
Compound 4: middle estimate off by 8 percentage points, on the high side; low and high end bracket the measured number.
By their numbers in this assay, from the lowest: compound 1; then compounds 2, 4 and 3 (each within the scatter of the next).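

In this assay, chloro entering on the benzyl arm, para to a large group, gives a number 0.5 percentage points lower from compound 3 to compound 4 (within the scatter) and so leaves the read-out of the 4-chlorobenzyl compound unresolved from that of its parent. The only earlier halogen step on this ring, a number 14.4 percentage points higher from compound 1 to compound 2 (beyond the scatter), involved fluoro on a differently substituted core, and its rise beyond the scatter does not recur here, so halogen on this ring does not raise the number in every setting shown. No measurement at hand says why the two steps differ.

The compounds shown leave open whether fluoro on the benzyl arm of compound 3 would match chloro or repeat the earlier rise. They also leave open how an amine or a carboxylic acid at this place would read in this assay.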